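The compounds below may be only part of what the source reports. "The series", "measured", "known", "first", "only" and "open" are said of these compounds alone.

Measured compounds:
compound 1 `COc1cc(C)cc(-c2nn(CC#N)cc2-c2ccc(-c3cccc(C(C)=O)c3)nc2)c1`, 21%
compound 2 `Cc1cc(O)cc(-c2nn(CC#N)cc2-c2ccnc(-c3ccc(Oc4ccccc4)cc3)c2)c1`, 35%
compound 3 `COc1cc(C)cc(-c2nn(CC#N)cc2-c2ccnc(-c3ccc(N(C)C)cc3)c2)c1`, 31%

All three were tested in a functional assay on OVCAR-5 cells (Homo sapiens) for cytotoxicity, read by sulforhodamine B assay, with a stated time of 48 h, tested at 1 uM; on this read-out higher numbers stand for a weaker effect at the one concentration tested and lower numbers for a stronger effect. Compound 3 gives 31% in this assay. That number lies between the numbers of compound 2 and compound 1, and the gap to each of them is within the usual scatter, so on these three numbers compound 3 cannot be told apart from either of the others.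

Compound 4 `Cc1cc(O)cc(-c2nn(CC#N)cc2-c2ccnc(-c3ccc(N(C)C)cc3)c2)c1` has not yet been measured. It differs from compound 3 in one place: hydrogen in place of methyl on an oxygen on an aromatic ring. Going by the values given here, the same feature is already present in compound 2, whose number in this assay sits close to that of compound 3, but compound 2 also differs from compound 3 elsewhere, so no pair of measured compounds isolates this change on its own. With nothing pointing either way, the change is expected to leave the read-out about where compound 3 stands, within the scatter, and the step of a number 2 percentage points higher from compound 3 to compound 4 (within the scatter) is the expected size. Compound 4 is therefore estimated to give 33% in this assay, with a range from 20% to 48%.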

Compound 4, a percentage reported as activity, at one concentration (the size of the read-out at that concentration, not a potency): 64%
For compound 4 the middle estimate is 31 percentage points below the measured one; measured number outside the range, above it.
By their numbers in this assay, from the lowest: compounds 1, 3 and 2 (each within the scatter of the next, the first and the last beyond it); then compound 4.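

In this assay the change from methoxy to hydroxy on the 3-methoxy-5-methylphenyl group can now be read on its own, and it comes out as a number 33 percentage points higher from compound 3 to compound 4 (beyond the scatter), so losing just the methyl on that oxygen clearly weakens the effect at the one concentration tested. The hydroxy group alone does not fix the read-out, since with hydroxy kept in place, dimethylamino in place of phenoxy on an aromatic carbon gives a number 29 percentage points higher from compound 2 to compound 4 (beyond the scatter), which shows that the group at this second place counts as well. Nothing at hand offers a reason for either step.

From the compounds shown here alone, it remains open whether the change from methoxy to hydroxy would have the same size in a compound that carries phenoxy instead of dimethylamino, so the two steps cannot yet be treated as independent of each other. Also open, going by these compounds, is how other groups at the same place would read, such as an ethoxy group, a longer ether chain or an amine standing in for the hydroxy.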